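A few compounds are considered here, and "the series" means these few. Any claim that something is new, unique, unknown or untested is made for them only; others in the source may bear on it.

Measured compounds in the series:
- compound 1 `COc1ccc(C)cc1N1C(=O)CSC1c1cccc(C(=O)NCCCCc2ccccc2)c1`: 30%
- compound 2 `O=C(NCCCCc1ccccc1)c1cccc(C2SCC(=O)N2c2ccccc2)c1`: 68%
- compound 3 `COc1cc(F)ccc1N1C(=O)CSC1c1cccc(C(=O)NCCCCc2ccccc2)c1`: 34%

In a functional assay on U2OS cells (Homo sapiens) for inhibition, read by CCK-8 assay, with a stated time of 72 h, tested at 1 uM (a lower number here means less inhibition, a higher number more inhibition at the concentration tested (going by the name of the read-out)), compound 1 gives 30%, the lowest of the three numbers. Compound 3 gives 34%, and the step of a number 4 percentage points higher from compound 1 to compound 3 (within the scatter) is within the scatter, so the two stand together. Compound 2 gives 68%, and the step of a number 38 percentage points higher from compound 1 to compound 2 (beyond the scatter) is large; likewise a number 34 percentage points lower from compound 2 to compound 3 (beyond the scatter) is large in the other direction.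

Compound 4 `O=C(NCCCCc1ccccc1)c1cccc(C2SCC(=O)N2c2cccc(F)c2)c1` is not yet measured. It differs from compound 1 by 3-fluorophenyl in place of 2-methoxy-5-methylphenyl on an amide-type nitrogen in a ring.

Among the measured compounds shown here, the steps that bear on this change are those from compound 1 and compound 3 to compound 2, where the group on the amide-type nitrogen in the ring is reduced to a bare phenyl: a number 38 percentage points higher from compound 1 to compound 2 (beyond the scatter) and a number 34 percentage points lower from compound 2 to compound 3 (beyond the scatter). For the measured compounds named here, a 3-fluorophenyl keeps the shape of that smaller group, so in this assay a step upward from compound 1 is expected, of a size close to that seen toward compound 2, though with only three compounds the margin is wide. The expected step is a number 28 percentage points higher from compound 1 to compound 4 (beyond the scatter). For compound 4 the estimate is 58%, between 40% and 75%.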

Compound 4, a percentage reported as inhibition, at one concentration (the size of the read-out at that concentration, not a potency): 39%
The estimate for compound 4 lay 19 percentage points above the measured number; measured number below the stated range.
By their numbers in this assay, from the lowest: compounds 1, 3 and 4 (each within the scatter of the next); then compound 2.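

In this assay, fluoro in place of hydrogen on an aromatic carbon gives a number 29 percentage points lower from compound 2 to compound 4 (beyond the scatter), so the high number of compound 2 does not carry over to this close analogue, and a bare phenyl and a 3-fluorophenyl on the ring nitrogen are not interchangeable here. With 3-fluorophenyl in place of 2-methoxy-5-methylphenyl the result is a number 9 percentage points higher from compound 1 to compound 4 (within the scatter), and with 3-fluorophenyl in place of 4-fluoro-2-methoxyphenyl it is a number 5 percentage points higher from compound 3 to compound 4 (within the scatter), so among the four compounds only compound 2 stands apart, and removing the methoxy group does not by itself raise the number. Nothing available explains why a single fluoro has this effect.

Open, on these data alone, is whether a chloro or a methyl group in place of that fluoro would also bring the number down. Also open, as far as these compounds go, is whether the gap between compound 2 and compound 4 would hold with a shorter chain on the amide of the shared core.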